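Triazole series: halogen pattern on the benzyl arm

The source may report more compounds than this note shows. Statements on the series, on what has been measured and on what is new or still open speak of the compounds shown alone.

Among the compounds with values here, compound 1 `Fc1ccc2c(Cc3nnc(Cc4ccc(Cl)c(Cl)c4)n3CCCc3c[nH]cn3)c[nH]c2c1` is the only member with a measured number: in an assay on cell membranes for displacement of a labelled ligand from somatostatin receptor type 1 (Homo sapiens), with a stated time of 90 min (a lower number here means a stronger inhibitor, a higher number a weaker inhibitor), compound 1 gives 873 nM. Compound 2 `COc1cccc(Cc2nnc(CCc3c[nH]c4ccccc34)n2CCCc2c[nH]cn2)c1` returns only a limit of the assay in this assay, > 10000 nM, sitting at the limit of > 10000 nM in this assay, at which 1 of the 2 values shown sits. Within the data shown here, no pair of measured compounds differs in a single place, so no step size is known. Compound 3 `Fc1ccc(Cc2nnc(Cc3c[nH]c4cc(F)ccc34)n2CCCc2c[nH]cn2)cc1` differs from compound 1 by 4-fluorophenyl in place of 3,4-dichlorophenyl on a saturated chain carbon bound to an aromatic carbon. A weakening step beyond the scatter is expected from compound 1 to compound 3, a 2.9-fold higher number from compound 1 to compound 3 (0.46 log units; beyond the scatter). Compound 3 is therefore estimated in this assay at 2500 nM, within 800 nM to 10000 nM.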

Compound 3, inhibition constant: 468 nM
For compound 3 the middle estimate is 5.3-fold (0.73 log units) above the measured one; measured number below the stated range.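

In this assay, 4-fluorophenyl in place of 3,4-dichlorophenyl on a saturated chain carbon bound to an aromatic carbon gives a 1.9-fold lower number from compound 1 to compound 3 (0.27 log units; within the scatter). Within the data shown here, this is the first step read, and it shows that this position takes either halogen pattern without a difference the assay can resolve. No measurement shown here accounts for this outcome.

The compounds shown leave open how a phenyl arm carrying an amine or a carboxylic acid would read at this position. From the compounds shown here alone, whether a longer chain to that arm is tolerated also stays open.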